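One Halogen Swapped on a Methoxyphenyl Ring

The compounds below may be only part of what the source reports. "The series", "measured", "known", "first", "only" and "open" are said of these compounds alone.

Compound 1 `COc1ccc(S(=O)(=O)NCCN2CCC(CCC(=O)c3cc(Cl)c(N)cc3OC)CC2)cc1Cl` is the reference point. Within the data shown here, in an assay on HEK293 cells for displacement of a labelled ligand from 5-hydroxytryptamine receptor 6 (Homo sapiens), with a stated time of 60 min, tested at 1 uM, in the presence of a further agent that is not named here (a higher number here means a stronger effect of the compound at the concentration tested, a lower number a weaker effect), compound 1 gives 85%, the only number reported among the two measured compounds. Compound 2 `COc1ccc(S(=O)(=O)N2CCC(CCC(=O)c3cc(Cl)c(N)cc3OC)CC2)cc1` was reported in this assay as "not active" (no number reported), without a number. Compound 3 `COc1ccc(S(=O)(=O)NCCN2CCC(CCC(=O)c3cc(Cl)c(N)cc3OC)CC2)cc1Br` differs from compound 1 in one place: bromo in place of chloro on an aromatic carbon. Among the measured compounds shown here, no measured pair shows the effect of exchanging one halogen for another here, so only a small step is expected in this assay, no change at the digits printed from compound 1 to compound 3 (within the scatter), not beyond the usual scatter. Compound 3 is therefore estimated at 85%, with a likely range from 65% to 97%.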

Compound 3, a percentage reported as inhibition, at one concentration (the size of the read-out at that concentration, not a potency): 72%
Estimate against measurement, compound 3: 13 percentage points above, and the stated range covers the measured number.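

In this assay the halogen on this ring is not interchangeable: going from 3-chloro-4-methoxyphenyl to 3-bromo-4-methoxyphenyl gives a number 13 percentage points lower from compound 1 to compound 3 (beyond the scatter) at the one concentration tested. This position, ortho to a methoxy group, therefore responds to the identity of the halogen, yet compound 3 still gives 72% in this test. No supporting data explain this step.

Still open, as far as these compounds go, is how a smaller fluoro group, or a methyl or nitrile group, would fare at this position. A read-out at a single concentration also leaves the potencies of compound 1 and compound 3 unknown.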